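The compounds below may be only part of what the source reports. "The series", "measured", "known", "first", "only" and "open" are said of these compounds alone.

Three members of a single series have been tested in a functional assay on MGC-803 cells (Homo sapiens) for inhibition, read by MTT assay, with a stated time of 72 h (a higher number here means a weaker inhibitor, a lower number a stronger inhibitor), so far, all sharing a chalcone-like scaffold. Compound 1 `O=C(/C=C/c1cccs1)c1ccc(OCCSC(=S)N2CCCC2)cc1` gives 32400 nM in this assay. Compound 2 `O=C(/C=C/c1ccc(Cl)cc1)c1ccc(OCCSC(=S)N2CCCC2)cc1` gives 47900 nM. Compound 3 `O=C(/C=C/c1ccc(Cl)cc1)c1ccc(OCCCSC(=S)N2CCCCC2)cc1` gives 56800 nM, the highest of the three numbers, though its nearest neighbour is compound 2 and neither gap reaches beyond the usual scatter.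

Two single-point changes connect these compounds. The first is thiophen-2-yl in place of 4-chlorophenyl on a double-bonded chain carbon bound to a double-bonded chain carbon, which produced a 1.5-fold lower number from compound 2 to compound 1 (0.17 log units; within the scatter). The second is a group of 10 heavy atoms (7 carbon, 1 nitrogen, 2 sulfur; one six-membered non-aromatic ring with 1 hetero atom) in place of a group of 8 heavy atoms (5 carbon, 1 nitrogen, 2 sulfur; one five-membered non-aromatic ring with 1 hetero atom), on a saturated chain carbon, two bonds along the chain from an oxygen on an aromatic ring, which produced a 1.2-fold higher number from compound 2 to compound 3 (0.07 log units; within the scatter); this is how the core of compound 3 differs from the core of compound 2.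

Compound 4 `O=C(/C=C/c1cccs1)c1ccc(OCCCSC(=S)N2CCCCC2)cc1` has not yet been measured in this assay. It is related to compound 3 by thiophen-2-yl in place of 4-chlorophenyl on a double-bonded chain carbon bound to a double-bonded chain carbon. This is the same change already seen from compound 2 to compound 1, made here on the core of compound 3 rather than on the core of compound 2; the place of the change is described in identical words in both cases.

Within the data shown here, because the earlier step was a 1.5-fold lower number from compound 2 to compound 1 (0.17 log units; within the scatter), a step of similar size is expected from compound 3 to compound 4, that is a 1.4-fold lower number from compound 3 to compound 4 (0.15 log units; within the scatter), resting on the single precedent and the observation that the core change from compound 2 to compound 3 stayed within the scatter. Compound 4 is therefore estimated at 40000 nM in this assay, with a plausible range from 20000 nM to 80000 nM.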

Compound 4, half-maximal inhibitory concentration: 41300 nM
Compound 4: middle estimate off by 1.0-fold (0.01 log units), on the low side; the range from low to high includes it.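

Thiophen-2-yl in place of 4-chlorophenyl on a double-bonded chain carbon bound to a double-bonded chain carbon gives, in this assay, a 1.4-fold lower number from compound 3 to compound 4 (0.14 log units; within the scatter), and the same change can now be compared on two cores: the same change on two cores in this assay, a 1.5-fold lower number (0.17 log units; within the scatter) from compound 2 to compound 1 and a 1.4-fold lower number (0.14 log units; within the scatter) from compound 3 to compound 4, 1.1-fold (0.03 log units) apart, within the scatter of two such steps

Within these two cores, then, the change carries over with no detectable difference in the size of the step, and the step read on the core of compound 2 was a fair guide to the one on the core of compound 3. This does not show that the change has a real effect on either core: each step lies within the scatter, so the agreement is also what would be seen if the swap did nothing, and two cores are too few to speak for the whole series.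

From the compounds shown here alone, the cores of compound 2 and compound 3 differ in the chain and in the ring at the same time, so what each of these contributes alone stays open, as does the behaviour of a still longer chain. Also open, going by these compounds, is whether other groups in place of thiophen-2-yl, such as furan-2-yl or 4-methoxyphenyl, would give a step that carries between cores in the same way.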